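Prenylated chalcone analogues: cytotoxicity in resistant breast cancer cells

A few compounds are considered here, and "the series" means these few. Any claim that something is new, unique, unknown or untested is made for them only; others in the source may bear on it.

Measured compounds:
compound 1 `COc1cc(OC)c(C(=O)/C=C/c2cccc(Cl)c2)c(O)c1CC=C(C)C`, 59500 nM
compound 2 `COc1cc(OC)c(C(=O)/C=C/c2cccc(N3CCNCC3)c2)c(O)c1C`, 98700 nM
compound 3 `COc1cc(OC)c(C(=O)/C=C/c2ccc(OC)c(OC)c2OC)c(O)c1CC=C(C)C`, 62700 nM

Three compounds on the shared core have been run in an ADME assay on MCF7-DOX cells (Homo sapiens) for cytotoxicity, read by MTT assay, with a stated time of 48 h; a lower number here means a stronger inhibitor, a higher number a weaker inhibitor. Compound 1 gives 59500 nM, compound 3 gives 62700 nM and compound 2 gives 98700 nM. Compound 1 stands at one end of the three numbers; compound 3 sits nearest to it and compound 2 furthest, but both gaps lie within the scatter of repeated runs, so the three read as level and no ranking among them is claimed. Weak inhibition is the common picture.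

Compound 4 `COc1cccc(/C=C/C(=O)c2c(OC)cc(OC)c(CC=C(C)C)c2O)c1` is not yet measured. Set against compound 1 the difference is methoxy in place of chloro on an aromatic carbon. Within the data shown here, no pair of measured compounds differs in one place, so there is no step in this assay from which the weight of this change can be read directly. What the numbers do show is that the aryl portion can carry either a single chloro or three methoxy groups, compound 1 and compound 3, without moving this assay beyond the scatter. On that ground the step is expected to be small, in no set direction, and the expected move a 1.1-fold higher number from compound 1 to compound 4 (0.04 log units; within the scatter) stays within the scatter. For compound 4 the estimate in this assay is 65000 nM, with a range from 30000 nM to 140000 nM.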

Compound 4, half-maximal inhibitory concentration: 49200 nM
The estimate for compound 4 lay 1.3-fold (0.12 log units) above the measured number; the range from low to high includes it.
By their numbers in this assay, from the lowest: compounds 4, 1, 3 and 2 (each within the scatter of the next).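

Among these compounds, the step from 3-chlorophenyl to 3-methoxyphenyl is the first single-place change that can be read directly on the shared core: in this assay it amounts to a 1.2-fold lower number from compound 1 to compound 4 (0.08 log units; within the scatter). At this aromatic carbon, meta to a large group, chloro and methoxy therefore read as level, even though methoxy brings two heavy atoms in place of one and a hydrogen-bond acceptor that chloro does not have. No measurement at hand explains why this exchange leaves the two compounds level.

On these data alone, this one step covers only chloro and methoxy, so it remains open whether a carboxylic acid, an amine or a longer alkoxy chain at the same carbon would give a step beyond the scatter. Also open, as far as these compounds go, is whether the exchange of chloro for methoxy would read the same way on other compounds, where the rest of the structure differs.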